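Aryl change on the carbon double-bonded to nitrogen

The source may hold more compounds than are shown below. What is called first, only, known or untested is meant among the compounds shown, and "the series" means these compounds.

Compound 1 `CC1=CC[C@H](C(C)(C)NC(=S)NN)CC1` has no aryl group at the terminal nitrogen; in an ADME assay on Vero cells (Chlorocebus sabaeus) for inhibition, read by sulforhodamine B assay, with a stated time of 48 h (on this read-out higher numbers stand for weaker inhibition of growth and lower numbers for stronger inhibition of growth), compound 1 gives 49500 nM. Compound 2 `CC1=CC[C@H](C(C)(C)NC(=S)N/N=C/c2ccccc2O)CC1` carries 2-hydroxyphenyl on the carbon with a double bond to nitrogen, and in this assay compound 2 gives 3100 nM. Compound 3 `CC1=CC[C@H](C(C)(C)NC(=S)N/N=C/c2ccc(F)cc2)CC1` carries 4-fluorophenyl in that place. In this assay compound 3 reaches only the limit of the assay, > 100000 nM, so no number is known for it. Going by the values given here, the step of an at least 32-fold higher number from compound 2 to compound 3 (1.50 log units; beyond the scatter) is the one measured change that bears on the aryl group, and it ends at the limit of > 100000 nM in this assay, at which 1 of the 3 values shown sits. Compound 4 `CC1=CC[C@H](C(C)(C)NC(=S)N/N=C/c2cccs2)CC1` differs from compound 3 by thiophen-2-yl in place of 4-fluorophenyl on a carbon with a double bond to nitrogen. Among the compounds with values here, no measured pair sets thiophen-2-yl against any other group, so the direction of this change cannot be read from the series; the step of an at least 32-fold higher number from compound 2 to compound 3 (1.50 log units; beyond the scatter) shows only that the group in this position can move the number by a large amount. Compound 4 is therefore expected to stay near the weak end, with an estimated step of an at least 1.4-fold lower number from compound 3 to compound 4 (0.15 log units; that floor lies within the scatter) that is loosely bounded. Compound 4 is estimated at 70000 nM, between 15000 nM and 300000 nM, and a limit-only result is about as likely as a number.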

Compound 4, concentration for 50% growth inhibition: 10100 nM
Compound 4: the middle estimate sits 6.9-fold (0.84 log units) above what was measured, outside the stated range (below it).
By their numbers in this assay, from the lowest: compound 2; then compound 4; then compound 1. At a limit, above all of these: compound 3.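

In this assay, the step of an at least 9.9-fold lower number from compound 3 to compound 4 (0.99 log units; beyond the scatter) starts from a limit, so it gives a floor and not a size: the limit of > 100000 nM in this assay, at which 1 of the 4 values shown sits.

Thiophen-2-yl gives a second measured number for an aromatic ring at this position: the step of a 3.3-fold higher number from compound 2 to compound 4 (0.51 log units; beyond the scatter) leaves it weaker than 2-hydroxyphenyl, while the step of a 4.9-fold lower number from compound 1 to compound 4 (0.69 log units; beyond the scatter) makes it stronger than the compound with no aryl group. A hydroxyl group on the ring is therefore not required for a measured number among these compounds, and 4-fluorophenyl alone ends at the limit.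

Still open, from the compounds shown here alone, is whether the gap between 2-hydroxyphenyl and 4-fluorophenyl follows the hydroxyl group, the fluorine or the place of substitution. Unsubstituted phenyl, 2-fluorophenyl and 4-hydroxyphenyl on the same carbon would separate these, and furan-2-yl would test whether the result for thiophen-2-yl extends to another five-membered ring.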